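The compounds below may be only part of what the source reports. "The series", "measured", "known", "first", "only" and "open" are said of these compounds alone.

Measured compounds:
- compound 1, `CCn1c(-c2ccccc2)nc2c(NC3CCCCC3)ncnc21`: 707 nM
- compound 2, `CCn1c(-c2ccccc2)nc2c(NC3CCC3)ncnc21`: 84 nM
- compound 3, `CCn1c(-c2ccccc2)nc2c(NC3CCOC3)ncnc21`: 1660 nM

All three share one core and differ only in the group on the ring nitrogen. In an assay on CHO cells for displacement of a labelled ligand from adenosine receptor A3 (Homo sapiens), read by scintillation counting, with a stated time of 3 h (on this read-out higher numbers stand for weaker inhibition and lower numbers for stronger inhibition), compound 3 stands highest of the three numbers; the nearest is compound 1, as in a 2.3-fold higher number from compound 1 to compound 3 (0.37 log units; beyond the scatter), and the furthest is compound 2, as in a 20-fold higher number from compound 2 to compound 3 (1.30 log units; beyond the scatter). Within the carbocycles the smaller ring gave the lower number, an 8.4-fold lower number from compound 1 to compound 2 (0.93 log units; beyond the scatter).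

Compound 4, `CCn1c(-c2ccccc2)nc2c(N)ncnc21`, takes the next step: hydrogen in place of oxolan-3-yl on a nitrogen on an aromatic ring. Among the compounds with values here, no measured step removes the ring substituent altogether, so none bears on this change directly; the steps that exist only compare one ring with another. The series gives no footing for extrapolating from the cyclobutyl result to a bare amino group, and such a group lies outside the range the three compounds cover. A step beyond the scatter is expected in this assay, and the direction taken here is toward a higher number, a 2.4-fold higher number from compound 3 to compound 4 (0.38 log units; beyond the scatter), with wide uncertainty. Compound 4 is therefore estimated at 4000 nM, within 800 nM to 20000 nM.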

Compound 4, inhibition constant: 5780 nM
Compound 4: middle estimate off by 1.4-fold (0.16 log units), on the low side; measured number inside the range.
By their numbers in this assay, from the lowest: compound 2; then compound 1; then compound 3; then compound 4.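

In this assay, taking the ring off this nitrogen altogether gives the highest number of the four, with a 3.5-fold higher number from compound 3 to compound 4 (0.54 log units; beyond the scatter), so even the oxolan-3-yl group, the highest of the ringed compounds, stands lower than the bare amino group. The two carbocycles lie further from the bare amino group, with an 8.2-fold higher number from compound 1 to compound 4 (0.91 log units; beyond the scatter) and with a 69-fold higher number from compound 2 to compound 4 (1.84 log units; beyond the scatter), which gives the change from (oxolan-3-yl)amino to amino a measured reference point for all three rings. Nothing available on these compounds accounts for the size of these steps. Cyclopentyl, the all-carbon counterpart of oxolan-3-yl, would show how much of the distance from compound 2 to compound 3 goes with the ring oxygen and how much with ring size. An open chain such as propyl on this nitrogen would show whether a ring is needed at all.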